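The source may report more compounds than this note shows. Statements on the series, on what has been measured and on what is new or still open speak of the compounds shown alone.

Compound 1 `Cc1ccc(CN2CCc3ncn(COCc4ccccc4)c3/C(=C/c3ccccc3)C2=O)cc1`: 21200 nM in a functional assay on A2780 cells (Homo sapiens) for inhibition, read by MTT assay, with a stated time of 72 h; on this read-out higher numbers stand for weaker inhibition and lower numbers for stronger inhibition. Compound 2 `COc1ccc(CN2CCc3ncn(COCc4ccccc4)c3/C(=C/c3ccccc3)C2=O)cc1`: 43100 nM in this assay.

Compound 1 holds the lowest of the two numbers; its nearest neighbour is compound 2, reached by a 2.0-fold higher number from compound 1 to compound 2 (0.31 log units; beyond the scatter). Compound 3 `O=C1/C(=C\c2ccccc2)c2c(ncn2COCc2ccccc2)CCN1Cc1ccc2ccccc2c1` differs from compound 1 by naphthalen-2-yl in place of 4-methylphenyl on a saturated chain carbon bound to an amide-type nitrogen in a ring. Within the data shown here, no measured step covers this change; the only step available, a 2.0-fold higher number from compound 1 to compound 2 (0.31 log units; beyond the scatter), concerns a different replacement, methoxy in place of methyl, and was modest. In this assay a step of at most similar size is therefore expected, in either direction or none beyond the scatter. Compound 3 is estimated at 15000 nM, within 5000 nM to 45000 nM, an expected step of a 1.4-fold lower number from compound 1 to compound 3 (0.15 log units; within the scatter).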

Compound 3, half-maximal inhibitory concentration: 72800 nM
Compound 3: middle estimate off by 4.9-fold (0.69 log units), on the low side; the measured number lies above the stated range.
By their numbers in this assay, from the lowest: compound 1; then compounds 2 and 3 (each within the scatter of the next).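

On a saturated chain carbon bound to an amide-type nitrogen in a ring, naphthalen-2-yl in place of 4-methylphenyl adds a second six-membered aromatic ring and gives a 3.4-fold higher number from compound 1 to compound 3 (0.54 log units; beyond the scatter) in this assay, so here the added ring goes with weaker inhibition. Against the 4-methoxyphenyl group, the same replacement gives a 1.7-fold higher number from compound 2 to compound 3 (0.23 log units; within the scatter), which leaves compound 2 and compound 3 unresolved. No evidence is available to explain either step.

Still open, as far as these compounds go, is whether an amine or a carboxylic acid on the 4-methylbenzyl group, or a longer chain in its place, would give a lower number than compound 1 does.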